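Amino for carboxy on the aryl tail: expected effect

A few compounds are considered here, and "the series" means these few. Any claim that something is new, unique, unknown or untested is made for them only; others in the source may bear on it.

Working notes on the series. Compound 1 `O=C(CCCCC#Cc1ccc([N+](=O)[O-])cc1)c1ncc(-c2ccccn2)o1` is the reference point: in an assay for inhibition of Fatty-acid amide hydrolase 1 (Rattus norvegicus) (on this read-out higher numbers stand for weaker inhibition and lower numbers for stronger inhibition), compound 1 gives 31 nM. Compound 2 `O=C(O)c1cccc(CCCCCCC(=O)c2ncc(-c3ccccn3)o2)c1` carries a different tail on the shared core, ending in a 3-carboxyphenyl. In this assay compound 2 reaches only a limit, > 600 nM, so no number is known for it. Where compound 2 stands on the numbers shown: it sits at the limit, as stated in the limit of > 600 nM in this assay, at which 1 of the 2 values shown sits, while compound 1 sits well inside the measurable range.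

Compound 3 `Nc1cccc(CCCCCCC(=O)c2ncc(-c3ccccn3)o2)c1` is the next member, not yet measured. It differs from compound 2 by amino in place of carboxy on an aromatic carbon of a six-membered aromatic ring of carbon only; read one bond further out, 3-carboxyphenyl becomes 3-aminophenyl. Within the data shown here, no measured pair carries this change, so the step size rests on expectation alone. The step from compound 2 to compound 3 is expected to be an at least 1.5-fold lower number from compound 2 to compound 3 (0.17 log units; that floor lies within the scatter), a gain beyond the scatter but uncertain in size. Compound 3 is expected at 400 nM, within a range from 100 nM to 2000 nM.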

Compound 3, inhibition constant: 30 nM
Compound 3: middle estimate off by 13-fold (1.12 log units), on the high side; measured number below the stated range.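

In this assay, exchanging carboxy for amino on an aromatic carbon gives an at least 20-fold lower number from compound 2 to compound 3 (1.30 log units; beyond the scatter), so the group at this place, meta to a large group, strongly affects the read-out. Among these compounds, with the chain, the phenyl ring and the shared core unchanged, this single exchange is enough to move the series from a limit to a measured number, which the earlier compounds, differing from each other in more than one place, could not show. The size of the step is a floor and not a measured gap, because compound 2 stands at a limit and not at a number: the limit of > 600 nM in this assay, at which 1 of the 3 values shown sits.

On these data alone, it remains open whether the step comes from gaining the amino group or from losing the carboxy group: an unsubstituted phenyl, or a hydroxy or methyl group on the same aromatic carbon, would separate the two. Among the compounds shown here, also open is whether the same exchange gives a similar step at another place on the ring or on a shorter chain, as this one pair is the only evidence for it.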